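Working notes: from compound 3 to compound 4

A few compounds are considered here, and "the series" means these few. Any claim that something is new, unique, unknown or untested is made for them only; others in the source may bear on it.

Measured so far in an ADME assay on MT4 cells (Homo sapiens) for cytotoxicity; on this read-out higher numbers stand for lower toxicity in this test and lower numbers for higher toxicity in this test
- compound 1 `FC(F)(F)c1cccc(NC(=S)Nc2ccc(Cl)cc2)c1` gives 6800 nM
- compound 2 `CCCC[C@H]1CC[C@H](c2ccc(NC(=S)Nc3cccc(C(F)(F)F)c3)cc2)CC1` gives 22000 nM
- compound 3 `FC(F)(F)c1cccc(NC(=S)Nc2ccccc2)c1` gives 39000 nM

Compound 3, at 39000 nM, cannot be separated from compound 2 within the scatter (a 1.8-fold higher number from compound 2 to compound 3 (0.25 log units; within the scatter)), but it stands clear of compound 1 (a 5.7-fold higher number from compound 1 to compound 3 (0.76 log units; beyond the scatter)).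

The next compound is compound 4 `Fc1ccc(NC(=S)Nc2cccc(C(F)(F)F)c2)cc1`, which has fluoro in place of hydrogen on an aromatic carbon, para to a large group (fluoro in place of hydrogen on an aromatic carbon).

The closest guide is chloro compound 1, the only measured halogen case in this comparison: a 5.7-fold higher number from compound 1 to compound 3 (0.76 log units; beyond the scatter). Read backwards, that step suggests that a halogen in place of hydrogen may bring a lower number. The other replacement of hydrogen gives a weaker signal: a 1.8-fold higher number from compound 2 to compound 3 (0.25 log units; within the scatter). Compound 2 therefore goes against any general rule that a new group in this place lowers the number. a 3.2-fold higher number from compound 1 to compound 2 (0.51 log units; beyond the scatter) also shows that the two substituted compounds differ from each other. Within the data shown here, no fluoro compound has been measured, so the chloro step is only a loose guide.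

A modest fall in this assay is expected, smaller than the chloro step and close to the edge of the scatter. The expected step is a 2.2-fold lower number from compound 3 to compound 4 (0.34 log units; beyond the scatter). The estimate for compound 4 is 18000 nM, with an expected range of 7000 nM to 40000 nM.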

Compound 4, half-maximal cytotoxic concentration: 31000 nM
Compound 4: the middle estimate sits 1.7-fold (0.24 log units) below what was measured; low and high end bracket the measured number.
By their numbers in this assay, from the lowest: compound 1; then compounds 2, 4 and 3 (each within the scatter of the next).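

In this assay, fluoro on this aromatic carbon, para to a large group, cannot be separated from hydrogen (a 1.3-fold lower number from compound 3 to compound 4 (0.10 log units; within the scatter)) or from 4-butylcyclohexyl (a 1.4-fold higher number from compound 2 to compound 4 (0.15 log units; within the scatter)). It does stand clear of chloro at the same place (a 4.6-fold higher number from compound 1 to compound 4 (0.66 log units; beyond the scatter)), so the earlier step from compound 1 to compound 3 does not amount to a rule for halogens in general: of the two halogens shown, only chloro goes with a separated number, and fluoro compound 4 goes against such a rule. Among these compounds, compound 1 is now the only one of the four compounds set apart from each of the others, while compounds 2, 3 and 4 remain within the scatter of one another, and no measured evidence bears on why the chloro compound stands apart.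

Whether the separation belongs to chloro alone remains open, as the compounds shown include no bromo, iodo, methyl or methoxy group at this place. Also open, from the compounds shown here alone, is how an amine or a carboxylic acid here would read in this assay, and whether the chloro gap would persist if the trifluoromethyl group of the shared core were replaced by a nitrile.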